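Hydroxy addition on the aryl ring: cytotoxicity notes

The source may report more compounds than this note shows. Statements on the series, on what has been measured and on what is new or still open speak of the compounds shown alone.

Measured so far:
compound 1 `O=[N+]([O-])C1=NNc2ncnn2C1c1ccc(O)c(O)c1` — in an ADME assay on MDCK cells (Canis lupus familiaris) for cytotoxicity (a higher number here means that more compound is tolerated, a lower number that less compound is tolerated), compound 1 gives > 1630000 nM, which is a limit of the assay and not a number.
compound 2 `O=[N+]([O-])C1=NNc2nc(C(F)(F)F)nn2C1c1c(O)cc(O)cc1O` — in this assay compound 2 gives 252000 nM.
compound 3 `O=[N+]([O-])C1=NNc2nc(C(F)(F)F)nn2C1c1ccc(O)cc1O` — in this assay compound 3 gives 108000 nM.

Compound 4 `O=[N+]([O-])C1=NNc2ncnn2C1c1ccc(O)c(O)c1O` has not yet been measured in this assay. It differs from compound 1 by hydroxy in place of hydrogen on an aromatic carbon. The same kind of change is seen between compound 3 and compound 2, (hydroxy in place of hydrogen on an aromatic carbon), where the measured step was a 2.3-fold higher number from compound 3 to compound 2 (0.37 log units; beyond the scatter). The places are not identical: in the pair of compound 1 and compound 4 the new hydroxy sits ortho to a hydroxy group, ortho to a large group and meta to a hydroxy group, whereas in the pair of compound 3 and compound 2 it sits ortho to a large group and meta to two hydroxy groups. The difference between the two cores is not broken down here.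

Because (the limit of > 1630000 nM in this assay, at which 1 of the 3 values shown sits), compound 1 gives only a limit, so any step from it cannot be read as a number. Given the modest rise a 2.3-fold higher number from compound 3 to compound 2 (0.37 log units; beyond the scatter), a step of about an at least 1.0-fold lower number from compound 1 to compound 4 (0.00 log units; that floor lies within the scatter) is expected, with the real chance that compound 4 again returns only a limit. Compound 4 is estimated at 1600000 nM, between 500000 nM and 4000000 nM.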

Compound 4, half-maximal cytotoxic concentration: 228000 nM
Compound 4: the middle estimate sits 7.0-fold (0.85 log units) above what was measured; the whole stated range lies above it.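

In this assay, hydroxy in place of hydrogen on an aromatic carbon gives an at least 7.1-fold lower number from compound 1 to compound 4 (0.85 log units; beyond the scatter), and this does not match the earlier step in direction or size: the same change on two cores in this assay, a 2.3-fold higher number (0.37 log units; beyond the scatter) from compound 3 to compound 2 and an at least 7.1-fold lower number (0.85 log units; beyond the scatter) from compound 1 to compound 4, at least 16-fold (1.22 log units) apart, beyond the scatter of two such steps. Compound 1 stands only at a limit of the assay, so the step from it has a floor and no exact size: the limit of > 1630000 nM in this assay, at which 1 of the 4 values shown sits. The two pairs differ in both core and place, with the new hydroxy in compound 4 ortho to a hydroxy group, ortho to a large group and meta to a hydroxy group, so the comparison shows that the change cannot be carried across unchanged but does not show whether core or place separates the two steps.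

The compounds shown leave open what the same hydroxy change does when only the core differs, or only the place. Also open, going by these compounds, is whether an amine or a methoxy group on the same aromatic carbon would move the tolerated concentration as hydroxy does.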